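A few compounds are considered here, and "the series" means these few. Any claim that something is new, unique, unknown or untested is made for them only; others in the source may bear on it.

The measured compounds:

compound 1, `O=S(=O)(c1cccc(F)c1)c1ccc2c(c1)CCC[C@H]2CNCCO`: 0.126 nM
compound 2, `CN(C)C(=O)NC[C@@H]1CCCc2cc(S(=O)(=O)c3cccc(F)c3)ccc21`: 2.51 nM
compound 3, `O=C(CO)NC[C@@H]1CCCc2cc(S(=O)(=O)c3cccc(F)c3)ccc21`: 0.1 nM

In an assay on isolated protein for displacement of a labelled ligand from 5-hydroxytryptamine receptor 6 (Homo sapiens) (a higher number here means a weaker inhibitor, a lower number a stronger inhibitor), compound 3 stands at the lowest of the three numbers. Its nearest neighbour is compound 1, within the scatter of it, since a 1.3-fold lower number from compound 1 to compound 3 (0.10 log units; within the scatter); its furthest is compound 2, since a 25-fold lower number from compound 2 to compound 3 (1.40 log units; beyond the scatter).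

Compound 4, `CN(C[C@@H]1CCCc2cc(S(=O)(=O)c3cccc(F)c3)ccc21)S(C)(=O)=O`, is not yet measured. It differs from compound 3 in one place: methyl(methylsulfonyl)amino in place of ((hydroxymethyl)carbonyl)amino on a saturated chain carbon bound to a saturated ring carbon. Going by the values given here, two measured steps bear on it. The first is a 20-fold higher number from compound 1 to compound 2 (1.30 log units; beyond the scatter), the second is a 25-fold lower number from compound 2 to compound 3 (1.40 log units; beyond the scatter). Both large steps separate the two compounds carrying a hydroxyl group, compounds 1 and 3, from compound 2, which carries none, and compound 4 carries none either. Among the compounds with values here, a step in this assay of comparable size, towards a higher number, is therefore expected for compound 4, though the entering group has no measured counterpart here, so the range is wide.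

Compound 4 is estimated at 2 nM, between 0.4 nM and 10 nM. That estimate means an expected step of a 20-fold higher number from compound 3 to compound 4 (1.30 log units; beyond the scatter).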

Compound 4, inhibition constant: 0.398 nM
Beside the measured number, compound 4's estimate is 5.0-fold (0.70 log units) above it; measured number outside the range, below it.
By their numbers in this assay, from the lowest: compounds 3 and 1 (each within the scatter of the next); then compound 4; then compound 2.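

In this assay, this position tolerates a group without a hydroxyl far better than compound 2 suggested: methyl(methylsulfonyl)amino, with 0 hydrogen-bond donors, gives only a 4.0-fold higher number from compound 3 to compound 4 (0.60 log units; beyond the scatter), and a 3.2-fold higher number from compound 1 to compound 4 (0.50 log units; beyond the scatter). Both compounds without a hydroxyl still give higher numbers than compounds 1 and 3, but they also differ from each other, with a 6.3-fold lower number from compound 2 to compound 4 (0.80 log units; beyond the scatter), so the absence of a hydroxyl does not fix the size of the step and the group that replaces it matters too. Nothing available explains why the methylsulfonyl group fares better than the dimethylcarbamoyl group.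

On these data alone, it remains open whether the methyl on the nitrogen of compound 4 contributes to its number, which the matching methylsulfonylamino group would test. An acetyl amide, compound 3 without its hydroxyl, would show directly what that hydroxyl adds.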